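The source may report more compounds than this note shows. Statements on the series, on what has been measured and on what is new or still open speak of the compounds shown alone.

Measured in a functional assay on NCI-H460 cells (Homo sapiens) for cytotoxicity, read by MTT assay, with a stated time of 72 h; on this read-out lower numbers stand for stronger inhibition and higher numbers for weaker inhibition:
- compound 1 `CN(C)Cc1ccc2nc(NC(=O)N/N=C/c3cn(Cc4ccc(C(C)(C)C)cc4)c4ccccc34)sc2c1`: 810 nM
- compound 2 `Cc1ccc(Cn2cc(/C=N/NC(=O)Nc3nc4ccc(CN5CCC(C)CC5)cc4s3)c3ccccc32)cc1`: 410 nM
- compound 3 `CC1CCN(Cc2ccc3nc(NC(=O)N/N=C/c4cn(Cc5ccccc5)c5ccccc45)sc3c2)CC1`: 1910 nM

Of these three, compound 3 has the highest number, at 1910 nM, and both of the others lie below it by more than the scatter. The next compound, compound 4 `CC1CCN(Cc2ccc3nc(NC(=O)N/N=C/c4cn(Cc5ccc(C(C)(C)C)cc5)c5ccccc45)sc3c2)CC1`, is built from compound 3 by one change: tert-butyl in place of hydrogen on an aromatic carbon. The benzyl thus becomes a 4-(tert-butyl)benzyl.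

Among the compounds with values here, one measured step bears directly on this change: a 4.7-fold higher number from compound 2 to compound 3 (0.67 log units; beyond the scatter), where hydrogen replaces methyl on an aromatic carbon. Read in reverse, this modest step says that a small alkyl group in place of that hydrogen goes with a lower number, and compound 2 stands at 410 nM. Whether a tert-butyl group behaves like methyl has not been measured on this scaffold. Compound 1 also carries a 4-(tert-butyl)benzyl and gives 810 nM, but it differs elsewhere too, so it is only a loose guide.

A modest move towards a lower number in this assay is therefore expected, of about the size seen with methyl. The expected change is a 4.0-fold lower number from compound 3 to compound 4 (0.60 log units; beyond the scatter). For compound 4 the estimated value is 480 nM, with an expected range from 190 nM to 1200 nM.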

Compound 4, half-maximal inhibitory concentration: 3370 nM
Compound 4: middle estimate off by 7.0-fold (0.85 log units), on the low side; measured number above the stated range.
By their numbers in this assay, from the lowest: compounds 2 and 1 (each within the scatter of the next); then compounds 3 and 4 (each within the scatter of the next).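

In this assay, tert-butyl in place of hydrogen on the benzyl of compound 3 gives a 1.8-fold higher number from compound 3 to compound 4 (0.25 log units; within the scatter) and so does not separate from hydrogen at this position, which sets it apart from methyl, where the step read a 4.7-fold higher number from compound 2 to compound 3 (0.67 log units; beyond the scatter). The two alkyl groups themselves stand clearly apart, with an 8.2-fold higher number from compound 2 to compound 4 (0.91 log units; beyond the scatter), so in these compounds what methyl does at this position does not carry over to tert-butyl. With the 4-(tert-butyl)benzyl held fixed, the amine also counts, since 4-methylpiperidin-1-yl in place of dimethylamino gives a 4.2-fold higher number from compound 1 to compound 4 (0.62 log units; beyond the scatter), and the number for compound 1 therefore said little about tert-butyl alongside 4-methylpiperidin-1-yl.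

Nothing given here accounts for these differences.

The compounds shown leave open whether an ethyl or isopropyl group at this position would stay with methyl or with tert-butyl, and how a methoxy group or a carboxylic acid there would compare. They also leave open whether methyl keeps its step when dimethylamino takes the place of 4-methylpiperidin-1-yl.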